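Cationic head-group swap on the shared core

A few compounds are considered here, and "the series" means these few. Any claim that something is new, unique, unknown or untested is made for them only; others in the source may bear on it.

In a functional assay (Oryctolagus cuniculus) for inhibition of platelet-activating factor receptor (Cavia porcellus) (on this read-out lower numbers stand for stronger inhibition and higher numbers for weaker inhibition), compound 1 `CCCCCCCCCCCCCCCCCC1OCC(COCCCCCC[n+]2ccccc2)O1` gives 3000 nM, and compound 2 `CCCCCCCCCCCCCCCCCC1OCC(COCCCCCCCC[n+]2ccsc2)O1` gives 3700 nM. Compound 2 holds the highest of the two numbers on this read-out, with compound 1 nearest, and the step of a 1.2-fold higher number from compound 1 to compound 2 (0.09 log units; within the scatter) sits within the scatter, so the two are not told apart. Compound 3 `CCCCCCCCCCCCCCCCCC1OCC(COCCCCCC[n+]2cccc3ccccc32)O1` has yet to be measured. Relative to compound 2 the change is a group of 10 heavy atoms (9 carbon, 1 nitrogen; one six-membered aromatic ring of carbon only, one six-membered aromatic ring with 1 hetero atom) in place of a group of 7 heavy atoms (5 carbon, 1 nitrogen, 1 sulfur; one five-membered aromatic ring with 2 hetero atoms), on a saturated chain carbon, six bonds along the chain from an oxygen on a saturated carbon. Among the measured compounds shown here, only one measured step bears on this move: it also exchanged the charged aromatic ring at the same place on the chain, and it came to a 1.2-fold higher number from compound 1 to compound 2 (0.09 log units; within the scatter), within the scatter. For the measured compounds named here, the change to compound 3 enlarges the ring system rather than exchanging one small ring for another, so the single precedent is an imperfect guide, but nothing measured points to a shift beyond the scatter. For compound 3 the expected step of a 1.2-fold lower number from compound 2 to compound 3 (0.09 log units; within the scatter) is therefore small. Compound 3 is estimated at 3000 nM, with a range from 1000 nM to 9000 nM.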

Compound 3, half-maximal inhibitory concentration: 2700 nM
Compound 3: the middle estimate sits 1.1-fold (0.05 log units) above what was measured, within the range that was stated.
By their numbers in this assay, from the lowest: compounds 3, 1 and 2 (each within the scatter of the next).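

Adding a six-membered aromatic ring of carbon only to the charged head group is a larger change than the ring exchange seen earlier, yet in this assay it produces a 1.1-fold lower number from compound 1 to compound 3 (0.05 log units; within the scatter) and leaves the number in the same range. The other route to the fused head group, replacing the five-membered aromatic ring with 2 hetero atoms, gives a 1.4-fold lower number from compound 2 to compound 3 (0.14 log units; within the scatter) and so also stays inside the scatter. At this place, on a saturated chain carbon, six bonds along the chain from an oxygen on a saturated carbon, charged aromatic groups of 6, 7 and 10 heavy atoms are therefore not told apart, and no information is available to explain this result.

All three head groups are aromatic and carry a net charge of +1, so the compounds shown leave open whether a trimethylammonium group, with its charge outside any aromatic ring, or a neutral tertiary amine at this place would move the number beyond the scatter. On these data alone, a carboxylic acid, which would replace the cationic head group with an acidic one, is equally open, as is whether any head group can give a clearly lower number on the shared core.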